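The source may report more compounds than this note shows. Statements on the series, on what has been measured and on what is new or still open speak of the compounds shown alone.

Measured compounds and their values in a functional assay on LS174T cells (Homo sapiens) for antiproliferative activity, with a stated time of 4 days; on this read-out lower numbers stand for stronger inhibition and higher numbers for weaker inhibition:

compound 1, `CN(C)c1ccc(C#Cc2ccccc2F)cc1`, gives 39 nM
compound 2, `CN(C)c1ccc(C#Cc2ccccc2Cl)cc1`, gives 31 nM
compound 3, `CN(C)c1ccc(C#Cc2c(F)cccc2F)cc1`, gives 23 nM

Within the data shown here, compound 3 sits at the low end of these three numbers, but its neighbours are close: compound 2 is within the usual scatter of it, and so is compound 1, so no compound of the three can be set apart from the others on this read-out.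

Compound 4, `CN(C)c1ccc(C#Cc2c(F)cccc2Cl)cc1`, differs from compound 3 by a single exchange: chloro in place of fluoro on an aromatic carbon. Among the measured compounds shown here, one measured step bears directly on this change. The same exchange of chloro for fluoro on an aromatic carbon has been seen once before, from compound 1 to compound 2, where it gave a 1.3-fold lower number from compound 1 to compound 2 (0.10 log units; within the scatter), a shift that stays within the scatter. The second fluoro group of compound 3 is carried over unchanged into compound 4, and the step from compound 1 to compound 3 measured a 1.7-fold lower number from compound 1 to compound 3 (0.23 log units; within the scatter), also within the scatter.

Compound 4 is therefore expected to show no step beyond the scatter in this assay, at most a slight drift toward a lower number in line with the earlier exchange. The estimate for compound 4 is 19 nM, with a range from 8 nM to 45 nM. That estimate corresponds to an expected step of a 1.2-fold lower number from compound 3 to compound 4 (0.08 log units; within the scatter).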

Compound 4, half-maximal inhibitory concentration: 19 nM
Beside the measured number, compound 4's estimate shows no gap at the digits printed; measured number inside the range.
By their numbers in this assay, from the lowest: compounds 4, 3, 2 and 1 (each within the scatter of the next, the first and the last beyond it).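

With a fluoro group already present, exchanging the other fluoro group for a chloro group, ortho to a large group, gives in this assay a 1.2-fold lower number from compound 3 to compound 4 (0.08 log units; within the scatter), so the exchange reads the same with and without that fluoro group: the same change on two cores in this assay, a 1.3-fold lower number (0.10 log units; within the scatter) from compound 1 to compound 2 and a 1.2-fold lower number (0.08 log units; within the scatter) from compound 3 to compound 4, 1.0-fold (0.02 log units) apart, within the scatter of two such steps Read the other way, fluoro in place of hydrogen gives a 1.6-fold lower number from compound 2 to compound 4 (0.21 log units; within the scatter) in the presence of the chloro group, which repeats the step seen without it: the same change on two cores in this assay, a 1.7-fold lower number (0.23 log units; within the scatter) from compound 1 to compound 3 and a 1.6-fold lower number (0.21 log units; within the scatter) from compound 2 to compound 4, 1.0-fold (0.02 log units) apart, within the scatter of two such steps Chloro in place of hydrogen gives a 2.1-fold lower number from compound 1 to compound 4 (0.31 log units; beyond the scatter), the only step among these four compounds that lies beyond the scatter, and a modest one, whereas fluoro in place of hydrogen on the same core gives a 1.7-fold lower number from compound 1 to compound 3 (0.23 log units; within the scatter) and stays within it.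

The compounds shown carry only hydrogen, fluoro and chloro at these places, so they leave open whether a bromo, a methyl or a methoxy group there would hold these numbers. They also leave open how the numbers respond when the shared core itself changes, for example with an amide in place of the alkyne.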